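Working notes: oxan-4-yl for 3-methoxypropyl on the ring nitrogen

The source may report more compounds than this note shows. Statements on the series, on what has been measured and on what is new or still open speak of the compounds shown alone.

Measured so far:
compound 1 `Cn1cc(-c2ccc(NC(=O)c3cn(CC4CCOCC4)cc(-c4ccc(F)cc4F)c3=O)cc2)c2c(N)ncnc21`: 0.8 nM
compound 2 `CCCn1cc(-c2ccc(NC(=O)c3cn(CC4CCOCC4)cc(-c4ccc(F)cc4)c3=O)cc2)c2c(N)ncnc21`: 1.8 nM
compound 3 `COCCCn1cc(C(=O)Nc2ccc(-c3cn(C)c4ncnc(N)c34)cc2)c(=O)c(-c2ccc(F)cc2)c1`: > 10 nM

In an assay on isolated protein for inhibition of tyrosine-protein kinase receptor UFO (Homo sapiens), read by ELISA (a lower number here means a stronger inhibitor, a higher number a weaker inhibitor), compound 1 gives 0.8 nM and compound 2 gives 1.8 nM; these two sit within the scatter of each other. For compound 3 the value > 10 nM is a limit of this assay, not a number. For the measured compounds named here, compound 3 therefore stands alone at the weak end of what has been measured (the limit of > 10 nM in this assay, at which 1 of the 3 values shown sits), with no measured step leading to it from compound 1 or compound 2.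

Compound 4 `Cn1cc(-c2ccc(NC(=O)c3cn(C4CCOCC4)cc(-c4ccc(F)cc4)c3=O)cc2)c2c(N)ncnc21` is not yet measured. The change from compound 3 is oxan-4-yl in place of 3-methoxypropyl on an aromatic nitrogen. Going by the values given here, no step between measured compounds covers this change, so the expected direction rests only on compound 3 standing at the limit: a move toward lower numbers, likely beyond the scatter, is expected. The estimated step is an at least 3.3-fold lower number from compound 3 to compound 4 (0.52 log units; beyond the scatter). Compound 4 is expected to give 3 nM in this assay, between 1 nM and 15 nM.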

Compound 4, half-maximal inhibitory concentration: 1.1 nM
Compound 4: the middle estimate sits 2.7-fold (0.44 log units) above what was measured, within the range that was stated.
By their numbers in this assay, from the lowest: compounds 1, 4 and 2 (each within the scatter of the next, the first and the last beyond it). At a limit, above all of these: compound 3.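

Placing oxan-4-yl in place of 3-methoxypropyl on the aromatic nitrogen gives an at least 9.0-fold lower number from compound 3 to compound 4 (0.95 log units; beyond the scatter) in this assay. For the compounds shown here, this is the only measured step at this position, and it shows that swapping the open chain for the six-membered non-aromatic ring moves the number beyond the scatter. For compound 3 the value is a limit, not a number: the limit of > 10 nM in this assay, at which 1 of the 4 values shown sits.

On these data alone, the full size of the step remains open. Also open, as far as these compounds go, is how a cyclohexyl group, which lacks the ring oxygen, or a piperidin-4-yl group, a ring amine, would read at this position.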